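Aryl swaps on the ring nitrogen and microsomal half-life

The source may hold more compounds than are shown below. What is called first, only, known or untested is meant among the compounds shown, and "the series" means these compounds.

Within the data shown here, compound 3 `O=C(NCCCCN1CCN(c2cccc(O)c2)CC1)c1ccc(-c2ccsc2)cc1` stands second highest of the three numbers so far in an ADME assay on microsomes from liver (Rattus norvegicus) for metabolic stability, read by LC-MS, using NADPH; on this read-out higher numbers stand for a longer-lived compound and lower numbers for a shorter-lived compound: compound 3 gives 0.085 h. Compound 1 `O=C(NCCCCN1CCN(c2ccc(Cl)cc2Cl)CC1)c1ccc(-c2ccsc2)cc1` gives 0.3 h, and compound 2 `COc1ccccc1N1CCN(CCCCNC(=O)c2ccc(-c3ccsc3)cc2)CC1` gives 0.04 h. Among the measured steps, a 3.5-fold lower number from compound 1 to compound 3 (0.55 log units; beyond the scatter) and a 2.1-fold higher number from compound 2 to compound 3 (0.33 log units; beyond the scatter) place compound 3 between the other two, while a 7.5-fold lower number from compound 1 to compound 2 (0.88 log units; beyond the scatter) spans the whole set.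

Compound 4 `O=C(NCCCCN1CCN(c2ccccc2C(F)(F)F)CC1)c1ccc(-c2ccsc2)cc1` is not yet measured. The change from compound 3 is 2-(trifluoromethyl)phenyl in place of 3-hydroxyphenyl on an amine nitrogen in a ring. Among the measured compounds shown here, no measured step involves a trifluoromethyl group, so none bears directly on this change; the three steps that exchange the group on the ring nitrogen are all of modest size and run in both directions, which suggests the size of the coming step but not its direction. A step of modest size is therefore expected in this assay, with the direction left open, and the middle of the expectation is put between the numbers of compound 1 and compound 3. For compound 4 the expected value in this assay is 0.15 h, with a range from 0.05 h to 0.5 h. The step this expectation means is a 1.8-fold higher number from compound 3 to compound 4 (0.25 log units; within the scatter), an estimate rather than a measurement.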

Compound 4, half-life: 0.0667 h
The estimate for compound 4 lay 2.2-fold (0.35 log units) above the measured number, within the range that was stated.
By their numbers in this assay, from the lowest: compounds 2, 4 and 3 (each within the scatter of the next, the first and the last beyond it); then compound 1.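

In this assay, a 1.3-fold lower number from compound 3 to compound 4 (0.11 log units; within the scatter) and a 1.7-fold higher number from compound 2 to compound 4 (0.22 log units; within the scatter) leave compound 4 within the scatter of both neighbours, so 2-(trifluoromethyl)phenyl on the amine nitrogen in a ring cannot be told apart from either 3-hydroxyphenyl or 2-methoxyphenyl, even though those two groups differ beyond the scatter from each other. Among the groups shown at this place, only 2,4-dichlorophenyl now stands clear of all the others, with a 4.5-fold lower number from compound 1 to compound 4 (0.65 log units; beyond the scatter) adding a third step beyond the scatter from compound 1 and compound 1 holding the highest number of the four. No measurement available here accounts for these numbers.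

From the compounds shown here alone, it remains open whether a single chlorine on the phenyl ring, or a nitrile at this place, would group with compound 1 or with the other three compounds. Going by these compounds, with every comparison here confined to the group on the ring nitrogen, it is also open how a longer chain in the shared core would alter the half-life, and whether the order at this place would hold with that change.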